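Benzyloxycarbonyl in Place of Trifluoromethyl: An Expected Cytotoxicity Read-Out

The source may report more compounds than this note shows. Statements on the series, on what has been measured and on what is new or still open speak of the compounds shown alone.

Of the compounds shown here, two sharing one core have been measured in an ADME assay on HaCaT cells (Homo sapiens) for cytotoxicity, read by MTT assay, with a stated time of 48 h; on this read-out lower numbers stand for stronger inhibition and higher numbers for weaker inhibition. Compound 1 (`COc1ccc2[nH]c(-c3cn(-c4ccccc4)nc3-c3ccccc3)nc2c1`) reports only a limit, > 50000 nM. Among the measured compounds shown here, compound 2 (`FC(F)(F)c1ccc2[nH]c(-c3cn(-c4ccccc4)nc3-c3ccccc3)nc2c1`) gives 37200 nM, the only actual number so far from this assay, so it has no measured neighbour against which it can be placed exactly.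

Compound 3 (`O=C(OCc1ccccc1)c1ccc2[nH]c(-c3cn(-c4ccccc4)nc3-c3ccccc3)nc2c1`) differs from compound 2 by benzyloxycarbonyl in place of trifluoromethyl on an aromatic carbon.

For the measured compounds named here, only one measured step bears on this change, and it concerns a different exchange of groups: an at least 1.3-fold lower number from compound 1 to compound 2 (0.12 log units; that floor lies within the scatter). Going by these compounds, its true size remains open because the limit of > 50000 nM in this assay, at which 1 of the 2 values shown sits, marks where that step begins. Going by the values given here, since the one step available, an at least 1.3-fold lower number from compound 1 to compound 2 (0.12 log units; that floor lies within the scatter), does not go beyond the scatter, no step beyond the scatter is expected in this assay, in either direction.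

The expected step is a 1.1-fold lower number from compound 2 to compound 3 (0.03 log units; within the scatter). For compound 3 the estimated value is 35000 nM, with an expected range from 14000 nM to 70000 nM.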

Compound 3, half-maximal inhibitory concentration: > 50000 nM
Compound 3 ended at the assay's limit; the forecaster's own chance of this, stated with the estimate: 35%; middle value at least 1.4-fold (0.15 log units) away from the limit.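

In this assay, putting benzyloxycarbonyl in place of trifluoromethyl on this aromatic carbon gives an at least 1.3-fold higher number from compound 2 to compound 3 (0.12 log units; that floor lies within the scatter), so a group with more heavy atoms, an added aromatic ring and hydrogen-bond acceptors brought no lower number at this position. The result for compound 3 is a limit of the assay and not a number, so this step has only a floor, and the step between compound 1 and compound 3 cannot be read. Methoxy and benzyloxycarbonyl now both end at the limit, and trifluoromethyl in compound 2 is the only group at this position with an actual number, so any reading of the position rests on that single compound: the limit of > 50000 nM in this assay, at which 2 of the 3 values shown sit.

Going by these compounds, the true values behind the limits of compound 1 and compound 3 remain open, and with them the real size of the step to compound 3. Among the compounds shown here, also open is whether a carboxylic acid or an amine on the same aromatic carbon would give an actual number in this assay, and whether that number would differ from the one for compound 2 by more than the usual scatter.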